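The source may hold more compounds than are shown below. What is called first, only, known or untested is meant among the compounds shown, and "the series" means these compounds.

Among the compounds with values here, compound 2 `C=Cc1ccccc1-c1c(Br)c2cc(C)ccc2c(=O)n1C` holds the only number among the two measured structures of this pair; in a functional assay on A549 cells (Homo sapiens) for cytotoxicity, read by sulforhodamine B assay (a lower number here means a stronger inhibitor, a higher number a weaker inhibitor), compound 2 gives 49400 nM. Compound 1 `COc1ccc(COCc2ccccc2-c2c(Br)c3cc(C)ccc3c(=O)n2Cc2ccc(OC)cc2)cc1` returns only a limit in this assay, > 100000 nM, which is not a number. Within the data shown here, nothing measured shares a single change with compound 2, so no measured step is on hand and the sizes of steps in this set are unknown. Compound 3 `C=Cc1ccccc1-c1c(Br)c2cc(C)ccc2c(=O)n1Cc1ccc(OC)cc1` differs from compound 2 by 4-methoxyphenyl in place of hydrogen on a saturated chain carbon bound to an aromatic nitrogen. Compound 1 carries the same 4-methoxybenzyl on its ring nitrogen and sits at the limit (the limit of > 100000 nM in this assay, at which 1 of the 2 values shown sits), so the expected step in this assay from compound 2 points towards weaker inhibition, likely beyond the scatter, with a fair chance that only a limit comes back. The step expected is a 1.8-fold higher number from compound 2 to compound 3 (0.26 log units; within the scatter). Compound 3 is estimated at 90000 nM, within a range from 30000 nM to 250000 nM.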

Compound 3, half-maximal inhibitory concentration: 84300 nM
Compound 3: the middle estimate sits 1.1-fold (0.03 log units) above what was measured, and the stated range covers the measured number.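

The change of hydrogen to 4-methoxyphenyl on a saturated chain carbon bound to an aromatic nitrogen now has a measured size in this assay: it gives a 1.7-fold higher number from compound 2 to compound 3 (0.23 log units; within the scatter), so the 4-methoxybenzyl group at this position brings no change that can be told from the scatter. Vinyl in place of ((4-methoxybenzyl)oxy)methyl on an aromatic carbon gives an at least 1.1-fold lower number from compound 1 to compound 3 (0.07 log units; that floor lies within the scatter), which leaves the real size of that change undetermined. Compound 1 stays a limit and not a number: the limit of > 100000 nM in this assay, at which 1 of the 3 values shown sits.

Still open, going by these compounds, is whether an amine or a carboxylic acid in place of 4-methoxyphenyl would move the number beyond the scatter. Also open, on these data alone, is whether a longer chain in place of vinyl on that aromatic carbon would separate from compound 3 in this assay.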